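Aryl ester on the pyrimidine phenyl: two-carbon linker variant

The compounds below may be only part of what the source reports. "The series", "measured", "known", "first", "only" and "open" are said of these compounds alone.

Measured so far in a functional assay on HT-29 cells (Homo sapiens) for antiproliferative activity, read by sulforhodamine B assay, with a stated time of 48 h; a higher number here means a weaker inhibitor of growth, a lower number a stronger inhibitor of growth:
- compound 1, `CCOC(=O)c1ccc(-c2cc(N3CCC(CNS(N)(=O)=O)CC3)ncn2)cc1`: compound 1 gives 5700 nM
- compound 2, `NS(=O)(=O)NCC1CCN(c2cc(-c3cccc(Cl)c3)ncn2)CC1`: compound 2 gives 47500 nM
- compound 3, `NS(=O)(=O)NCCC1CCN(c2cc(-c3ccccc3)ncn2)CC1`: compound 3 gives 66500 nM

Compound 3 has the highest number of the three in this assay, but compound 2 lies within the scatter of it, so no order between those two can be read. Compound 1 sits lower by a gap beyond the scatter; it differs from compound 3 in two places at once, the ester on the phenyl and the length of the chain to the sulfamide, so its value only shows what the two together give.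

Compound 4, `COC(=O)c1ccc(-c2cc(N3CCC(CCNS(N)(=O)=O)CC3)ncn2)cc1`, differs from compound 3 by methoxycarbonyl in place of hydrogen on an aromatic carbon. For the measured compounds named here, no measured pair isolates this change. A step to a lower number, beyond the scatter, is expected from compound 3 to compound 4 because compound 1 gives 5700 nM with an ester at that place; the expected step is a 5.5-fold lower number from compound 3 to compound 4 (0.74 log units; beyond the scatter). Compound 4 is estimated at 12000 nM, within a range from 3500 nM to 40000 nM.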

Compound 4, concentration for 50% growth inhibition: 19600 nM
Estimate against measurement, compound 4: 1.6-fold (0.21 log units) below; low and high end bracket the measured number.
By their numbers in this assay, from the lowest: compound 1; then compound 4; then compounds 2 and 3 (each within the scatter of the next).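

In this assay, methoxycarbonyl in place of hydrogen on an aromatic carbon, para to a large group, gives a 3.4-fold lower number from compound 3 to compound 4 (0.53 log units; beyond the scatter). For the compounds shown here, this is the first change seen in one place alone: the gap between compound 1 and compound 3 mixed the ester with the chain length, whereas this pair shows that the ester alone moves the number beyond the scatter, by a modest step, on the chain of compound 3. Nothing available explains this step in terms of a measured property of the group.

The compounds shown hold no pair that tests whether the same step appears on the shorter chain of compound 1, or what ethoxycarbonyl gives on the chain of compound 4. On these data alone, a carboxylic acid or a primary amide at this place, or a still longer chain to the sulfamide, remains open.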